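The compounds below may be only part of what the source reports. "The series", "measured", "known", "first", "only" and "open" are said of these compounds alone.

Measured so far in a functional assay on A-431 cells (Homo sapiens) for cytotoxicity; on this read-out lower numbers stand for an effect already at smaller amounts and higher numbers for an effect only at larger amounts of compound:
- compound 1 `COC1=C(C)C(=O)/C(=C(O)/C=C/c2ccc(OC)cc2)C(=O)C1(C)C`: in this assay compound 1 gives 9.2 ug/mL
- compound 2 `COC1=C(C)C(=O)/C(=C(O)/C=C/c2ccccc2OC)C(=O)C1(C)C`: in this assay compound 2 gives 6.6 ug/mL
- compound 3 `CCc1ccc(/C=C/C(O)=C2/C(=O)C(C)=C(OC)C(C)(C)C2=O)cc1`: in this assay compound 3 gives 12 ug/mL

The three compounds share one core and differ only in the aromatic group on the double-bonded chain carbon. Compound 2 sits among the others with no gap that the assay would resolve: from compound 1 a 1.4-fold lower number from compound 1 to compound 2 (0.14 log units; within the scatter), and from compound 2 onward a 1.8-fold higher number from compound 2 to compound 3 (0.26 log units; within the scatter), both within the scatter, as is a 1.3-fold higher number from compound 1 to compound 3 (0.12 log units; within the scatter).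

Compound 4 `COC1=C(C)C(=O)/C(=C(O)/C=C/c2cccs2)C(=O)C1(C)C` takes the step from compound 2 described as thiophen-2-yl in place of 2-methoxyphenyl on a double-bonded chain carbon bound to a double-bonded chain carbon. Going by the values given here, the steps that bear on it are the two aryl exchanges already measured, from compound 1 to compound 2 and from compound 2 to compound 3, each within the scatter. A five-membered aromatic ring has not been tried in the series, so the parallel is loose, but nothing measured here points to a step beyond the scatter in this assay in either direction.

Compound 4 is therefore expected to give about 8.5 ug/mL in this assay, in a range from 3.5 ug/mL to 20 ug/mL. The estimated step from compound 2 to compound 4 is a 1.3-fold higher number from compound 2 to compound 4 (0.11 log units; within the scatter), which is expected to stay within the scatter.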

Compound 4, concentration for half-maximal effect: 10.8 ug/mL
Beside the measured number, compound 4's estimate is 1.3-fold (0.10 log units) below it, within the range that was stated.
By their numbers in this assay, from the lowest: compounds 2, 1, 4 and 3 (each within the scatter of the next).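

In this assay, going by these compounds alone, thiophen-2-yl, a five-membered aromatic ring with one hetero atom, stands on a double-bonded chain carbon bound to a double-bonded chain carbon with no resolved step against any of the six-membered aromatic groups (a 1.6-fold higher number from compound 2 to compound 4 (0.21 log units; within the scatter); a 1.2-fold higher number from compound 1 to compound 4 (0.07 log units; within the scatter); a 1.1-fold lower number from compound 3 to compound 4 (0.05 log units; within the scatter)). The range of tolerated groups at this place therefore now extends from carbon-only six-membered rings of 8 heavy atoms to a sulfur-containing ring of 5 heavy atoms. Nothing available gives a reason for this flat result.

With every step here within the scatter, the compounds shown support no ranking of groups at this place. Going by these compounds, whether a non-aromatic group such as cyclohexyl, or an aromatic ring carrying an amine or a carboxylic acid, would give a step beyond the scatter remains open.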